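Acetoxy on the Chain: From Compound 2 to Compound 4

The compounds below may be only part of what the source reports. "The series", "measured", "known", "first", "only" and "open" are said of these compounds alone.

Three quinones have been tested in a functional assay on SAOS-2 cells (Homo sapiens) for cytotoxicity, read by MTT assay, with a stated time of 48 h; a lower number here means a stronger inhibitor, a higher number a weaker inhibitor. Compound 1 `CC(C)=CC[C@H](OC(=O)C=C(C)C)C1=CC(=O)c2c(O)ccc(O)c2C1=O` carries an ester on its chain and gives 840 nM. Compound 2 `COc1ccc(O)c2c1C(=O)C=C(CCC=C(C)C)C2=O` gives 20400 nM, and compound 3 `COc1ccc(O)c2c1C(=O)C(CCC=C(C)C)=CC2=O` gives 12500 nM. Compound 2 sits at the top end of these numbers: its gap to compound 3 lies within the usual scatter of this assay, whereas its gap to compound 1 lies well beyond it.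

Compound 4 `COc1ccc(O)c2c1C(=O)C=C([C@H](CC=C(C)C)OC(C)=O)C2=O` has not yet been measured. It differs from compound 2 in one place: acetoxy in place of hydrogen on a saturated chain carbon bound to a double-bonded ring carbon and a saturated chain carbon. For the measured compounds named here, compound 1 is the only measured compound that also carries an ester on its chain, and it gives 840 nM, so the expectation is that compound 4 will give a lower number than compound 2, with a step of a 2.6-fold lower number from compound 2 to compound 4 (0.41 log units; beyond the scatter) that is expected to reach beyond the scatter. The estimate for compound 4 in this assay is 8000 nM, within a range from 2500 nM to 25000 nM.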

Compound 4, half-maximal inhibitory concentration: 13800 nM
For compound 4 the middle estimate is 1.7-fold (0.24 log units) below the measured one, and the stated range covers the measured number.
By their numbers in this assay, from the lowest: compound 1; then compounds 3, 4 and 2 (each within the scatter of the next).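

In this assay, acetoxy in place of hydrogen on this saturated chain carbon gives a 1.5-fold lower number from compound 2 to compound 4 (0.17 log units; within the scatter), so the step cannot be told apart from repeat measurement. For the compounds shown here, this is the first comparison of compounds that differ in one place, and it shows that this carbon can carry acetoxy, with its 4 heavy atoms, without a difference beyond the scatter. Nothing measured here explains why the step is this small.

Going by these compounds, whether a hydroxyl, an amine or a longer ester on this carbon would give a step beyond the scatter remains open. On these data alone, compound 1 differs from compound 4 in more than one place, so the part played by its chain ester cannot be read here, and how acetoxy would act on the chain of compound 3 also stays open.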